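The source may hold more compounds than are shown below. What is called first, only, known or untested is meant among the compounds shown, and "the series" means these compounds.

Compound 1 `CCOc1ccc(NC(=O)Nc2cc(C(C)(C)C)nn2-c2ccccc2)cc1` — in an assay on isolated protein for inhibition of STE20-like serine/threonine-protein kinase (Homo sapiens), read by thermal shift assay, tested at 10 uM (a lower number here means that the compound stabilises the target less, a higher number that the compound stabilises the target more against heat), compound 1 gives 1.1 degrees C
Compound 2 `CC(C)(C)c1cc(NC(=O)Nc2ccc(Cl)cc2)n(-c2ccc(C(F)(F)F)cc2)n1` — in this assay compound 2 gives 0.7 degrees C

Both compounds share a core that carries a tert-butyl group and a urea linking two aromatic rings, and both give only small shifts in this assay. The two values lie within the scatter of each other, so compound 2 is not set apart from compound 1 on these numbers; nothing in the pair points to a direction.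

Compound 3 `CC(C)(C)c1cc(NC(=O)Nc2ccc(Cl)cc2)n(-c2ccc(S(C)(=O)=O)cc2)n1` has not yet been measured. It differs from compound 2 in one place: methylsulfonyl in place of trifluoromethyl on an aromatic carbon. Within the data shown here, no measured pair shows what this kind of change does in this assay, so the expectation rests only on the two values in hand, which sit close together and close to the bottom of the range. The step from compound 2 to compound 3 is therefore expected to be small, a number 0.10 degrees C higher from compound 2 to compound 3 (within the scatter), with no clear direction and not beyond the scatter. Compound 3 is estimated to give 0.8 degrees C in this assay, between -0.3 degrees C and 1.9 degrees C.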

Compound 3, shift of the target's melting temperature: 5.2 degrees C
Compound 3: the middle estimate sits 4.4 degrees C below what was measured; measured number above the stated range.
By their numbers in this assay, from the lowest: compounds 2 and 1 (each within the scatter of the next); then compound 3.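

Placing methylsulfonyl instead of trifluoromethyl on this aromatic carbon, para to a large group, gives a number 4.5 degrees C higher from compound 2 to compound 3 (beyond the scatter) in this assay, so the group held at this position can strongly change the thermal stabilisation of the target. Compounds 1 and 2 differ in more than one place and offered no such single-change reading, whereas this pair isolates the effect of one substituent. The two groups match in heavy-atom count, while methylsulfonyl brings two hydrogen-bond acceptors and trifluoromethyl none, but no measurement here ties the gain to that difference or to any other feature of the change.

On these data alone, it remains open whether the gain requires the complete methylsulfonyl group, a question that a sulfonamide, a carboxylic acid, an amine or a nitrile at this same position would help to answer, as would a longer chain on the sulfur in place of the methyl. As far as these compounds go, it is also open whether the same change would give a comparable gain when the other aromatic ring carries the ethoxy group of compound 1 rather than the chlorine of compound 2.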